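Notes on one ring exchange at compound 1

The source may hold more compounds than are shown below. What is called first, only, known or untested is meant among the compounds shown, and "the series" means these compounds.

Among the measured compounds shown here, only two numbers exist so far. In a functional assay on A549 cells (Homo sapiens) for cytotoxicity, read by LDH release, with a stated time of 48 h (a lower number here means a stronger inhibitor, a higher number a weaker inhibitor), compound 1 (`Cn1cnc(C(=O)NNC(=O)COc2ccc(C(=O)c3ccccc3)cc2)c1`) gives 31600 nM and compound 2 (`Cc1ccc(C(=O)c2cc(F)c(OCC(=O)NNC(=O)c3ccc(=O)oc3)c(Cl)c2)cc1`) gives 21400 nM as the measured pair. For the measured compounds named here, these two values lie within the scatter of each other, so compound 1 stands level with the only other measured compound.

Compound 3 (`O=C(COc1ccc(C(=O)c2ccccc2)cc1)NNC(=O)c1ccc(=O)oc1`) keeps the core of compound 1 and differs in one group on a carbonyl carbon. The change (a group of 7 heavy atoms (5 carbon, 2 oxygen; one six-membered aromatic ring with 1 hetero atom) in place of a group of 6 heavy atoms (4 carbon, 2 nitrogen; one five-membered aromatic ring with 2 hetero atoms), on a carbonyl carbon) takes away the 1-methyl-1H-imidazol-4-yl group, and the group that enters has no common name.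

Going by the values given here, no measured pair shows this exchange alone. Compound 2 carries the same entering group on a core with other substituents, and its value of 21400 nM stays within the scatter of compound 1. No step beyond the scatter is therefore expected in this assay for this exchange. The estimated size of a 1.1-fold lower number from compound 1 to compound 3 (0.05 log units; within the scatter) is expected to stay inside the scatter. For compound 3 the estimate is 28000 nM with an expected range from 12000 nM to 60000 nM as a working figure.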

Compound 3, half-maximal inhibitory concentration: 90900 nM
The estimate for compound 3 lay 3.2-fold (0.51 log units) below the measured number, outside the stated range (above it).
By their numbers in this assay, from the lowest: compounds 2 and 1 (each within the scatter of the next); then compound 3.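

In this assay, among the compounds shown here, the exchange on a carbonyl carbon whose other neighbour is an amide-type nitrogen gives a 2.9-fold higher number from compound 1 to compound 3 (0.46 log units; beyond the scatter), the first reading of this change alone on an otherwise unchanged core. This position therefore responds to the group placed on it, with the 1-methyl-1H-imidazol-4-yl group giving the lower number, even though the leaving and entering groups have the same counted hydrogen-bond donors, hydrogen-bond acceptors and net charge. Nothing available here bears on the reason for this step.

For the compounds shown here, the single step does not separate the contributions of ring size, hetero atoms and the double bond outside aromatic rings, and a pyridin-3-yl group or a 1H-imidazol-4-yl group without the methyl on the same carbonyl carbon would test those differences more narrowly. On these data alone, whether the step carries over to the substituted core of compound 2 also stays open, as does whether any group at this position gives a number beyond the scatter below that of compound 1 in this assay.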